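Swapping fluoro for methyl on the carbonyl-bearing ring

A few compounds are considered here, and "the series" means these few. Any claim that something is new, unique, unknown or untested is made for them only; others in the source may bear on it.

Compound 1 `COc1cc(N(Cc2nc3ccccc3[nH]2)S(=O)(=O)c2ccc(C)cc2)cc(OC)c1OC`: 5400 nM
Compound 2 `COc1cc(N(Cc2nc3ccccc3[nH]2)C(=O)c2ccc(F)cc2)cc(OC)c1OC`: 45200 nM

In a functional assay on MCF7 cells (Homo sapiens) for inhibition, read by MTT assay, with a stated time of 48 h (a higher number here means a weaker inhibitor, a lower number a stronger inhibitor), compound 2 gives the higher of the two numbers, with compound 1 the nearer comparison an 8.4-fold higher number from compound 1 to compound 2 (0.92 log units; beyond the scatter). Compound 3 `COc1cc(N(Cc2nc3ccccc3[nH]2)C(=O)c2ccc(C)cc2)cc(OC)c1OC` differs from compound 2 by methyl in place of fluoro on an aromatic carbon. Within the data shown here, no measured step isolates this change; the only step, from compound 1 to compound 2, swaps sulfonyl for carbonyl together with the ring substituent, so it gives no clean guide. The step from compound 2 to compound 3 is therefore expected to stay within the scatter a 1.1-fold lower number from compound 2 to compound 3 (0.05 log units; within the scatter). Compound 3 is estimated at 40000 nM, between 13000 nM and 120000 nM.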

Compound 3, half-maximal inhibitory concentration: 49300 nM
Estimate against measurement, compound 3: 1.2-fold (0.09 log units) below, within the range that was stated.
By their numbers in this assay, from the lowest: compound 1; then compounds 2 and 3 (each within the scatter of the next).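

With the carbonyl held in place, methyl in place of fluoro on this aromatic carbon makes no difference that can be told from scatter in this assay, with a 1.1-fold higher number from compound 2 to compound 3 (0.04 log units; within the scatter). Compound 3 also allows a clean comparison with compound 1, where only sulfonyl gives way to carbonyl, and there a 9.1-fold higher number from compound 1 to compound 3 (0.96 log units; beyond the scatter), so the gap follows that link rather than the ring substituent. Nothing available explains either result. From the compounds shown here alone, whether an amine or a carboxylic acid on this aromatic carbon would shift the number remains open, as does whether fluoro and methyl would also match on the sulfonyl compounds.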